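Replacing the 1-hydroxypropyl group: from compound 3 to compound 4

A few compounds are considered here, and "the series" means these few. Any claim that something is new, unique, unknown or untested is made for them only; others in the source may bear on it.

Of the compounds shown here, three on one shared core form the series so far: compound 1 (`CCc1ccc2oc(CSc3nnc(CNc4ccccc4)n3CC)nc2c1`), compound 2 (`CC/C(=N/OC)c1ccc2oc(CSc3nnc(CNc4ccccc4)n3CC)nc2c1`) and compound 3 (`CCC(O)c1ccc2oc(CSc3nnc(CNc4ccccc4)n3CC)nc2c1`). In an ADME assay on blood (Rattus norvegicus) for metabolic stability, with a stated time of 2 h (on this read-out lower numbers stand for a less stable compound and higher numbers for a more stable compound), compound 1 gives "not determined" (no result reported). In the same read-out compound 2 gives "not determined" (no result reported). Going by the values given here, compound 3 gives 80%, the only number, so it serves as a single reference point and cannot be ranked against any neighbour.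

The next compound is compound 4 (`CCn1c(CNc2ccccc2)nnc1SCc1nc2cc(Cl)ccc2o1`), still to be measured in this assay. The change is chloro in place of 1-hydroxypropyl on an aromatic carbon. The rest of the structure stays the same.

Among the compounds with values here, the series contains no measured pair that differs in one place, so the data give no scale for this change. Without such a pair, no step beyond the usual scatter is expected, and neither direction is favoured. The expectation starts from compound 3 at 80%, and the range stays wide since it rests on that one number. The expected step is a number 2 percentage points lower from compound 3 to compound 4 (within the scatter), which stays within the scatter. For compound 4 the estimate is 78%, with an expected range of 55% to 95%.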

Compound 4, percent of the compound remaining: 92%
For compound 4 the middle estimate is 14 percentage points below the measured one; the measured number falls inside the stated range.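

In this assay the series now has its first pair that differs in one place, and chloro in place of 1-hydroxypropyl on an aromatic carbon gives a number 12 percentage points higher from compound 3 to compound 4 (beyond the scatter) as a modest step. On this single pair, the 1-hydroxypropyl group is not required for the compound to stay intact in blood at this position, and the shorter chloro substituent is tolerated without any loss on this read-out. No measured property in the series bears on why the number moved, and one pair cannot separate the removal of 1-hydroxypropyl from the arrival of chloro.

Steps to compound 1 and compound 2 cannot be read, as neither carries a number, so the ethyl and the methoxyimino-bearing substituents give no further scale at this position. Going by these compounds, whether the step holds as a trend remains open: a fluoro or methoxy group, an amine or a carboxylic acid on the same aromatic carbon could show whether the reading follows chloro specifically or simply the absence of 1-hydroxypropyl.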